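The source may hold more compounds than are shown below. What is called first, only, known or untested is meant among the compounds shown, and "the series" means these compounds.

Of the compounds shown here, three of a shared core have been measured, and a fourth awaits its number. Compound 1 `COc1cc2c(cc1OC)C(CC(=O)O)CC2` carries a carboxylic acid on its side chain, compound 2 `CCNC(=O)CC1CCc2cc(OC)c(OC)cc21` an ethylamino group on the same carbonyl carbon, and compound 3 `COc1cc2c(cc1OC)C(CC(=O)NC1CCCC1)CC2` a cyclopentylamino group there. In a functional assay on the whole organism (strain Wistar) for inhibition, with Rattus norvegicus as the target, read by paw edema, with stated times of 60 min and 6 h, at a dose of 100 mg/kg by the oral route (on this read-out higher numbers stand for more inhibition at the one dose given (going by the name of the read-out) and lower numbers for less inhibition), compound 1 gives 20.4%, and compound 2 gives 20.4%. Compound 3 gives 40.7%. Compound 2 thus stands level with compound 1, the two together forming the low end of the three numbers, while compound 3 sits clearly higher.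

Among the measured steps, no change at the digits printed from compound 1 to compound 2 (within the scatter), whereas a number 20.3 percentage points higher from compound 1 to compound 3 (beyond the scatter) and a number 20.3 percentage points higher from compound 2 to compound 3 (beyond the scatter). Compound 4 `COc1cc2c(cc1OC)C(CC(=O)N1CCOCC1)CC2` is the next variation on compound 2: morpholin-4-yl in place of ethylamino on a carbonyl carbon. For the measured compounds named here, the step that bears most directly on it is the one from compound 2 to compound 3, where a larger ring-bearing group on the amide nitrogen raised the number modestly; the step from compound 1 to compound 2 shows that a small open-chain amide left it unchanged. Morpholin-4-yl brings a ring, but it is a different kind of amide substituent, so a modest rise at most is expected, with wide uncertainty, giving a number 10.6 percentage points higher from compound 2 to compound 4 (beyond the scatter). Compound 4 is therefore estimated at 31%, within a range from 14% to 50%.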

Compound 4, a percentage reported as inhibition, in the whole organism at one dose (the size of the read-out at that dose, not a potency): 14.8%
Compound 4: middle estimate off by 16.2 percentage points, on the high side; measured number inside the range.
By their numbers in this assay, from the lowest: compounds 4, 1 and 2 (each within the scatter of the next); then compound 3.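

Having a ring on the carbonyl carbon is clearly not enough to raise the number in this assay: morpholin-4-yl in place of cyclopentylamino gives a number 25.9 percentage points lower from compound 3 to compound 4 (beyond the scatter). The same group in place of ethylamino gives a number 5.6 percentage points lower from compound 2 to compound 4 (within the scatter), and in place of hydroxy it gives a number 5.6 percentage points lower from compound 1 to compound 4 (within the scatter), so among the amides only the cyclopentylamino group of compound 3 stands apart from the acid of compound 1. Nothing measured here explains why these groups behave differently at this place.

Morpholin-4-yl differs from cyclopentylamino in more than one way: it brings a ring oxygen and has no amide hydrogen, and the ring is joined through the amide nitrogen itself, so the compounds shown cannot separate these changes. A piperidin-1-yl group would have no ring oxygen and no amide hydrogen, while a tetrahydropyran-4-ylamino group would keep both, and these two would help show which of the differences goes with the lower number.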